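The source may report more compounds than this note shows. Statements on the series, on what has been measured and on what is new or still open speak of the compounds shown alone.

The measured compounds in an ADME assay on BJ cells (Homo sapiens) for inhibition, with a stated time of 72 h; on this read-out lower numbers stand for an effect already at smaller amounts and higher numbers for an effect only at larger amounts of compound:
Compound 1 `CN(C)CCC(=O)Nc1cccc(-c2nc3ccccc3s2)c1` gives > 25000 nM, a limit of the assay.
Compound 2 `O=C(CCl)Nc1cccc(-c2nc3ccccc3s2)c1` gives 8500 nM.
Compound 3 `CC(Cl)C(=O)Nc1cccc(-c2nc3ccccc3s2)c1` gives > 25000 nM, a limit of the assay.

Compound 1 thus stands at the limit (the limit of > 25000 nM in this assay, at which 2 of the 3 values shown sit), with no number of its own. Among the measured steps, an at least 2.9-fold lower number from compound 1 to compound 2 (0.46 log units; beyond the scatter) shows an at least modest move toward a smaller amount, whereas an at least 2.9-fold higher number from compound 2 to compound 3 (0.46 log units; beyond the scatter) goes back up, and a step that the two limits leave unreadable from compound 1 to compound 3 cannot be read between the two limits.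

Compound 4 `O=C(Nc1cccc(-c2nc3ccccc3s2)c1)c1ccnc(Cl)c1` differs from compound 1 by 2-chloropyridin-4-yl in place of 2-(dimethylamino)ethyl on a carbonyl carbon. Among the measured compounds shown here, no measured step exchanges the saturated chain on the carbonyl carbon for an aromatic ring, so the step from compound 1 to compound 2 gives only loose guidance: removing the (dimethylamino) group from compound 1 was enough for an at least modest change. The expected step is therefore an at least 1.6-fold lower number from compound 1 to compound 4 (0.22 log units; that floor lies within the scatter). Compound 4 is estimated at 15000 nM, with a range from 4000 nM to 40000 nM, and a real chance that this assay again reports only a limit.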

Compound 4, half-maximal effective concentration: > 25000 nM
Compound 4: no number, only a limit (the forecaster's own chance of this, stated with the estimate: 55%); middle value at least 1.6-fold (0.22 log units) away from the limit.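

In this assay, an aromatic ring on the carbonyl carbon can now be read against the chloromethyl group, and 2-chloropyridin-4-yl in place of chloromethyl gives an at least 2.9-fold higher number from compound 2 to compound 4 (0.46 log units; beyond the scatter). Compound 4 has only a limit of the assay, so a chlorine atom on the ring does not bring a number of its own, and compound 2 remains the only compound shown with one: the limit of > 25000 nM in this assay, at which 3 of the 4 values shown sit. The steps to compound 4 from compound 1 and from compound 3 cannot be read, as both ends of each are limits.

Going by these compounds, how far compound 1, compound 3 and compound 4 lie past that limit stays open. Also open, on these data alone, is whether the higher number of compound 4 goes with the pyridine ring or with its chlorine, which a plain pyridin-4-yl or phenyl group on the carbonyl carbon would address.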